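The source may hold more compounds than are shown below. What is called first, only, known or untested is meant among the compounds shown, and "the series" means these compounds.

Measured compounds in a functional assay on HTB-54 cells (Homo sapiens) for cytotoxicity, read by MTT assay, with a stated time of 72 h; on this read-out lower numbers stand for stronger inhibition of growth and higher numbers for weaker inhibition of growth:
compound 1 `CCCCOC(=O)Nc1ccc([Se]C#N)cc1` gives 43400 nM.
compound 2 `CC(C)COC(=O)Nc1ccc([Se]C#N)cc1` gives 51200 nM.
compound 3 `N#C[Se]c1ccc(NC(=O)OCc2ccc([N+](=O)[O-])cc2)cc1` gives 47600 nM.

All three compounds share the same selenocyanate-bearing core and differ only in the carbamate ester part. Compound 3 sits among the other two: its gap to compound 2 and its gap to compound 1 both lie within the scatter of this assay, so the three values cannot be told apart.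

Compound 4 `N#C[Se]c1ccc(NC(=O)OCc2ccccc2)cc1` is not yet measured. It differs from compound 3 as follows: hydrogen in place of nitro on an aromatic carbon.

For the measured compounds named here, the only step measured so far within one position, a 1.2-fold higher number from compound 1 to compound 2 (0.07 log units; within the scatter), concerns the ester chain and not the aromatic carbon changed here, so no measured step bears directly on the change from compound 3 to compound 4. Going by the values given here, that step and the gaps between all three compounds fall within the scatter, and the series so far gives no sign that the carbamate ester part moves this assay. For compound 4 a step of a 1.0-fold lower number from compound 3 to compound 4 (0.01 log units; within the scatter) is therefore expected, that is, none beyond the scatter. Compound 4 is estimated at 46000 nM, with a range from 20000 nM to 105000 nM.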

Compound 4, concentration for total growth inhibition: 50800 nM
Estimate against measurement, compound 4: 1.1-fold (0.04 log units) below, within the range that was stated.
By their numbers in this assay, from the lowest: compounds 1, 3, 4 and 2 (each within the scatter of the next).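

In this assay, the nitro group on the aromatic carbon para to a large group can be replaced by hydrogen without a change beyond the scatter, with a 1.1-fold higher number from compound 3 to compound 4 (0.03 log units; within the scatter). The phenyl group in the ester part also gives no separation from the saturated chains, with a 1.0-fold lower number from compound 2 to compound 4 (0.00 log units; within the scatter) and a 1.2-fold higher number from compound 1 to compound 4 (0.07 log units; within the scatter), so all four carbamates remain indistinguishable on this read-out. No supporting data are available to explain this flat result.

As far as these compounds go, only nitro and hydrogen are compared at this aromatic carbon, so an amine or a carboxylic acid there remains open, as does a longer chain in the ester part. The selenocyanate stays constant throughout, so these compounds cannot show what replacing it with a thiocyanate or a nitrile would do.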